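Trimming a methoxy from the aryl arm of compound 1

The source may report more compounds than this note shows. Statements on the series, on what has been measured and on what is new or still open speak of the compounds shown alone.

Going by the values given here, compound 1 `CCOC(=O)c1c(-c2ccc(OC)c(OC)c2)csc1N` has the higher of the two numbers measured so far in an assay on isolated protein for inhibition of protein kinase C zeta type (Homo sapiens), with stated times of 1 h and 2.5 min, tested at 30 uM (a higher number here means more inhibition at the concentration tested (going by the name of the read-out), a lower number less inhibition), where compound 1 gives 100%. Among the compounds with values here, its only measured neighbour is compound 2 `CCNC(=O)c1c(-c2ccc(OC)c(OC)c2)csc1N`, which differs by an ethylamino in place of ethoxy on a carbonyl carbon; in this assay compound 2 gives 50%, a drop of a number 50 percentage points lower from compound 1 to compound 2 (beyond the scatter).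

The next compound, compound 3 `CCOC(=O)c1c(-c2ccc(OC)cc2)csc1N`, differs from compound 1 elsewhere, on the six-membered aromatic ring of carbon only: hydrogen in place of methoxy on an aromatic carbon. Within the data shown here, the one measured step, from compound 1 to compound 2, concerns the carbonyl side of the shared core and says nothing directly about the aromatic ring, so no measured step bears on this change. With no guide beyond the high reading of compound 1, a small loss that may stay within the scatter is the most that can be expected, with a wider downside than upside since the reading of compound 1 sits at the top of the scale. Compound 3 is therefore expected to give about 85%, estimated between 55% and 100%. That estimate corresponds to an expected step of a number 15 percentage points lower from compound 1 to compound 3 (beyond the scatter).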

Compound 3, a percentage reported as inhibition, at one concentration (the size of the read-out at that concentration, not a potency): 100%
Beside the measured number, compound 3's estimate is 15 percentage points below it; low and high end bracket the measured number.
By their numbers in this assay, from the lowest: compound 2; then compounds 1 and 3 (each within the scatter of the next).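

On the six-membered aromatic ring of carbon only, hydrogen in place of methoxy gives no change at the digits printed from compound 1 to compound 3 (within the scatter) in this assay, so at the tested concentration this assay detects no need for the methoxy that stands meta to a large group. Going by these compounds alone, this is the first measured change on the aryl arm, and unlike a number 50 percentage points lower from compound 1 to compound 2 (beyond the scatter), on the carbonyl side, it leaves the reading where it was, with one fewer group on the ring. Both compound 1 and compound 3 sit at the top of the percentage scale, however, so a single reading at one concentration cannot show whether a difference in potency lies hidden there, and nothing measured here explains why the change leaves the reading in place.

Still open, as far as these compounds go, is whether the remaining methoxy can also be replaced by hydrogen, or exchanged for a hydroxyl group, a fluorine atom or an amine, and how a longer chain such as ethoxy would fare at the position trimmed here. The same trimming on the ethylamino compound 2, whose reading leaves room to move in both directions, is also unknown from the compounds shown.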